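A few compounds are considered here, and "the series" means these few. Any claim that something is new, unique, unknown or untested is made for them only; others in the source may bear on it.

Measured compounds:
Compound 1 `CCOc1ccc(NC2=CC(=O)c3c(nc4n3[C@H]3OC[C@@H](O)[C@H]3OC4)C2=O)cc1` gives 2090 nM in a functional assay on MGC-803 cells (Homo sapiens) for inhibition, read by sulforhodamine B assay; a lower number here means a stronger inhibitor, a higher number a weaker inhibitor.
Compound 2 `COc1ccccc1NC1=CC(=O)c2c(nc3n2[C@H]2OC[C@@H](O)[C@H]2OC3)C1=O` gives 1670 nM.
Compound 3 `Cc1ccc(NC2=CC(=O)c3c(nc4n3[C@H]3OC[C@@H](O)[C@H]3OC4)C2=O)cc1` gives 1550 nM.

Compound 3 sits at the low end of the three numbers, but its separation from the others is slight: the step of a 1.1-fold lower number from compound 2 to compound 3 (0.03 log units; within the scatter) and the step of a 1.3-fold lower number from compound 1 to compound 3 (0.13 log units; within the scatter) both lie within the scatter, as does a 1.3-fold lower number from compound 1 to compound 2 (0.10 log units; within the scatter). The three anilines on the shared core therefore give numbers that cannot be told apart.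

Compound 4 `O=C1C(Nc2ccc(I)cc2)=CC(=O)c2c1nc1n2[C@H]2OC[C@@H](O)[C@H]2OC1` is the next member. It differs from compound 3 by a single change on the aryl ring, (iodo in place of methyl on an aromatic carbon), so that the 4-methylphenyl group becomes 4-iodophenyl. Among the measured compounds shown here, no measured step involves an iodo group; the only step touching the same carbon, a 1.3-fold lower number from compound 1 to compound 3 (0.13 log units; within the scatter), swapped ethoxy for methyl and stayed within the scatter. With every change among the measured anilines leaving the number essentially unchanged, the expectation for compound 4 is a step of about a 1.0-fold lower number from compound 3 to compound 4 (0.01 log units; within the scatter), not beyond the scatter. Compound 4 is accordingly estimated at 1500 nM, within a range of 600 nM to 3800 nM.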

Compound 4, half-maximal inhibitory concentration: 2150 nM
Compound 4: middle estimate off by 1.4-fold (0.16 log units), on the low side; the measured number falls inside the stated range.
By their numbers in this assay, from the lowest: compounds 3, 2, 1 and 4 (each within the scatter of the next).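

Compound 4 carries iodo, the only halogen among the four compounds, and in this assay the swap for methyl on this aromatic carbon gives a 1.4-fold higher number from compound 3 to compound 4 (0.14 log units; within the scatter) and so stays inside the usual spread of repeat measurements. Set against the other two anilines, the 4-iodophenyl group gives a 1.3-fold higher number from compound 2 to compound 4 (0.11 log units; within the scatter) and also a 1.0-fold higher number from compound 1 to compound 4 (0.01 log units; within the scatter) on the same core, so the four compounds still cannot be told apart, and methyl, ethoxy and iodo on this carbon all read alike. Nothing measured here accounts for this sameness.

As far as these compounds go, whether an amine or a carboxylic acid on this carbon would also read alike remains open. So does whether a smaller halogen such as fluoro, or a longer chain than ethoxy, would stay within the same narrow band.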